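Cytotoxicity across the benzyl-substituted series

A few compounds are considered here, and "the series" means these few. Any claim that something is new, unique, unknown or untested is made for them only; others in the source may bear on it.

Compound 3 `Cc1c(Cc2ccc(-c3ccccc3)cc2)c(=O)oc2cc(OCC(O)CN3CCC(C(N)=O)CC3)ccc12` sits at the upper edge of what an ADME assay on A549 cells (Homo sapiens) for cytotoxicity, read by CellTiter-Glo (a higher number here means that more compound is tolerated, a lower number that less compound is tolerated), can read: in this assay compound 3 gives > 100000 nM, a limit rather than a number. Compound 2 `Cc1c(Cc2ccc(Br)cc2)c(=O)oc2cc(OCC(O)CN3CCC(C(N)=O)CC3)ccc12` likewise gives > 100000 nM, also a limit. Compound 1 `Cc1c(Cc2ccc(C(C)(C)C)cc2)c(=O)oc2cc(OCC(O)CN3CCC(C(N)=O)CC3)ccc12` gives 14700 nM. The steps of an at least 6.8-fold higher number from compound 1 to compound 2 (0.83 log units; beyond the scatter) and an at least 6.8-fold higher number from compound 1 to compound 3 (0.83 log units; beyond the scatter) are both beyond the scatter, whereas the step that the two limits leave unreadable from compound 2 to compound 3 cannot be sized, as the limit of > 100000 nM in this assay, at which 2 of the 3 values shown sit, records. Compound 4 `Cc1c(Cc2ccc(-c3ccc(Cl)cc3)cc2)c(=O)oc2cc(OCC(O)CN3CCC(C(N)=O)CC3)ccc12` differs from compound 3 by chloro in place of hydrogen on an aromatic carbon. Within the data shown here, no measured step alters the outer phenyl itself, so none bears directly on this change; the limit of compound 3 is the only anchor. The expected step of a number no higher from compound 3 to compound 4 (the limit leaves the size open) is therefore none beyond the scatter, and compound 4 is estimated at 100000 nM, with a range from 50000 nM to 200000 nM, most likely reported again only as a limit.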

Compound 4, half-maximal cytotoxic concentration: 32900 nM
Beside the measured number, compound 4's estimate is 3.0-fold (0.48 log units) above it, outside the stated range (below it).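

In this assay the outer phenyl turns out to respond to a single added heavy atom: chloro in place of hydrogen gives an at least 3.0-fold lower number from compound 3 to compound 4 (0.48 log units; beyond the scatter). The 4-chlorophenyl group also gives an at least 3.0-fold lower number from compound 2 to compound 4 (0.48 log units; beyond the scatter) in place of bromo, and a 2.2-fold higher number from compound 1 to compound 4 (0.35 log units; beyond the scatter) in place of tert-butyl, so compound 4 lies between compound 1 and the two limits. The full size of the first two steps stays open because both start from a limit: the limit of > 100000 nM in this assay, at which 2 of the 4 values shown sit.

As far as these compounds go, how a fluoro, a methoxy, an amine or a carboxylic acid at that place on the outer phenyl would read remains open.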